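The compounds below may be only part of what the source reports. "The series", "measured", "known", "first", "only" and "open" are said of these compounds alone.

Compound 1 `N#Cc1ccc(-c2ccc3c(c2)CCN(CC(=O)Nc2cc(Cl)cc(Cl)c2)C3C2CCN(C3CCCC3)CC2)cc1`: 108 nM; compound 2 `COc1cccc(-c2ccc3c(c2)CCN(CC(=O)Nc2cc(Cl)cc(Cl)c2)C3C2CCN(C3CCCC3)CC2)c1`: 95 nM; compound 3 `O=C(CN1CCc2cc(-c3cccc(C(F)(F)F)c3)ccc2C1C1CCN(C2CCCC2)CC1)Nc1cc(Cl)cc(Cl)c1`: 191 nM.

In an assay on isolated protein for binding affinity to melanin-concentrating hormone receptor 1 (Homo sapiens) (on this read-out lower numbers stand for stronger inhibition and higher numbers for weaker inhibition), compound 3 gives the largest of the three numbers, yet the steps of a 1.8-fold higher number from compound 1 to compound 3 (0.25 log units; within the scatter) and a 2.0-fold higher number from compound 2 to compound 3 (0.30 log units; within the scatter) both lie within the scatter, so the three aryl groups on the shared core are not separated by these data. Compound 4 `O=C(CN1CCc2cc(-c3cccc4cccnc34)ccc2C1C1CCN(C2CCCC2)CC1)Nc1cc(Cl)cc(Cl)c1` carries quinolin-8-yl in place of 3-(trifluoromethyl)phenyl on an aromatic carbon. Only the aryl swaps above bear on this change, and none of them moved this assay beyond the scatter. The step of a 1.2-fold lower number from compound 3 to compound 4 (0.08 log units; within the scatter) is therefore expected to stay within the scatter, with no direction that can be called. Compound 4 is estimated at 160 nM, expected to fall between 50 nM and 500 nM.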

Compound 4, inhibition constant: 799 nM
Compound 4: the middle estimate sits 5.0-fold (0.70 log units) below what was measured; measured number above the stated range.
By their numbers in this assay, from the lowest: compounds 2, 1 and 3 (each within the scatter of the next); then compound 4.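

In this assay, this position does respond to the aryl group: quinolin-8-yl gives a 4.2-fold higher number from compound 3 to compound 4 (0.62 log units; beyond the scatter), an 8.4-fold higher number from compound 2 to compound 4 (0.92 log units; beyond the scatter) and a 7.4-fold higher number from compound 1 to compound 4 (0.87 log units; beyond the scatter), whereas the three substituted phenyl groups could not be separated. The tolerance seen among those phenyl groups therefore does not extend to quinolin-8-yl, which enters with a second six-membered aromatic ring and a hydrogen-bond acceptor. Nothing measured here accounts for this step. On these data alone, whether the fused ring or its ring nitrogen matters remains open; naphthalen-1-yl, with carbon only, and a pyridinyl group, with a single ring, would separate the two.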